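Chain extension at the aryl ether of compound 2

This account rests on a few compounds, and the source may have more. Where it says the series, first, only, none or still open, it means among the compounds named here.

Measured so far in an assay on COS-7 cells for inhibition of sodium/nucleoside cotransporter 2 (Homo sapiens), read by scintillation counting; on this read-out lower numbers stand for stronger inhibition and higher numbers for weaker inhibition:
compound 1 `Nc1ncnc2c1nc(NCc1ccc(-c3ccccn3)cc1)n2[C@@H]1O[C@H](CO)[C@@H](O)[C@H]1O` gives 1500 nM
compound 2 `CCOc1cc(CNc2nc3c(N)ncnc3n2[C@@H]2O[C@H](CO)[C@@H](O)[C@H]2O)ccc1-c1ccccc1` gives 2300 nM
compound 3 `Nc1ncnc2c1nc(NCc1ccc(-c3ccccc3)cc1O)n2[C@@H]1O[C@H](CO)[C@@H](O)[C@H]1O` gives 1300 nM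

Compound 2 sits alongside compound 1 and compound 3: its gap to each of them lies within the scatter, so the three numbers are not distinguishable. Nothing has been measured as a single-change step among them.

Compound 4 `Nc1ncnc2c1nc(NCc1ccc(-c3ccccc3)c(OCCCCO)c1)n2[C@@H]1O[C@H](CO)[C@@H](O)[C@H]1O` is not yet measured. Its difference from compound 2 is 2-hydroxyethyl in place of hydrogen on a saturated chain carbon, two bonds along the chain from an oxygen on an aromatic ring. For the measured compounds named here, no measured pair shows this change, so no direction is known; the expectation is a step from compound 2 to compound 4 of a 1.2-fold lower number from compound 2 to compound 4 (0.06 log units; within the scatter), that is, none beyond the scatter. Compound 4 is accordingly estimated at 2000 nM in this assay, with a range from 800 nM to 5000 nM.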

Compound 4, half-maximal inhibitory concentration in the sodium/nucleoside cotransporter 2 assay: 940 nM
Estimate against measurement, compound 4: 2.1-fold (0.33 log units) above; measured number inside the range.
By their numbers in the sodium/nucleoside cotransporter 2 assay, from the lowest: compounds 4, 3, 1 and 2 (each within the scatter of the next, the first and the last beyond it).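

Ethoxy to 4-hydroxybutoxy at the aryl ether gives the first single-change step in the series: in the sodium/nucleoside cotransporter 2 assay compound 2 gives 2300 nM and compound 4 gives 940 nM, which reads a 2.4-fold lower number from compound 2 to compound 4 (0.39 log units; beyond the scatter). For the compounds shown here, this place on the chain therefore accepts 2-hydroxyethyl with a modest gain, which the earlier compounds could not show. In a physicochemical assay for solubility, with a stated time of 1 h, at 37 degrees C, at pH 6.8 (a lower number here means a less soluble compound, a higher number a more soluble compound), compound 2 gives 121 ug/mL and compound 4 gives 190 ug/mL; the same change reads a 1.6-fold higher number from compound 2 to compound 4 (0.20 log units; within the scatter), so no solubility change can be claimed.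

Nothing shown gives a cause for the step. Open, on these data alone, is whether the gain depends on the hydroxyl or on chain length alone, which a plain butoxy chain, or an amine or carboxylic acid in place of the hydroxyl, would test.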